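Removing the anilide nitro group from a weak cytotoxic agent

This account rests on a few compounds, and the source may have more. Where it says the series, first, only, none or still open, it means among the compounds named here.

Compound 1 `O=C(/C=C/C(=O)N1C/C(=C\c2ccccc2)C(=O)/C(=C/c2ccccc2)C1)Nc1ccc([N+](=O)[O-])cc1` is the weaker of the two measured compounds: in a functional assay on CCRF-CEM cells (Homo sapiens) for cytotoxicity (on this read-out higher numbers stand for weaker inhibition and lower numbers for stronger inhibition), compound 1 gives 40000 nM, whereas compound 2 `O=C(/C=C/C(=O)N1C/C(=C\c2ccc([N+](=O)[O-])cc2)C(=O)/C(=C/c2ccc([N+](=O)[O-])cc2)C1)Nc1ccc([N+](=O)[O-])cc1` gives 410 nM, a gap well beyond the scatter. Compound 3 `O=C(/C=C/C(=O)N1C/C(=C\c2ccccc2)C(=O)/C(=C/c2ccccc2)C1)Nc1ccccc1` differs from compound 1 by one change, (hydrogen in place of nitro on an aromatic carbon), that is, hydrogen in place of nitro on an aromatic carbon. Within the data shown here, no measured pair shows this change. Because compound 2 reaches 410 nM carrying two further nitro groups, removing a nitro is expected to weaken inhibition slightly. The expected step is a 1.5-fold higher number from compound 1 to compound 3 (0.18 log units; within the scatter), possibly none beyond the scatter. Compound 3 is estimated at 60000 nM, ranging from 20000 nM to 200000 nM.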

Compound 3, half-maximal inhibitory concentration: 1100 nM
For compound 3 the middle estimate is 55-fold (1.74 log units) above the measured one; measured number below the stated range.
By their numbers in this assay, from the lowest: compound 2; then compound 3; then compound 1.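

Going from 4-nitrophenyl to phenyl gives a 36-fold lower number from compound 1 to compound 3 (1.56 log units; beyond the scatter) in this assay, a large step. This position on the six-membered aromatic ring therefore matters strongly in the core of compound 1, and here the nitro group goes with the weaker inhibition. Nothing available accounts for the size or direction of this step. As far as these compounds go, whether an amine or a methoxy group at this place would read like hydrogen or like nitro stays open. Also open, from the compounds shown here alone, is whether the same change on compound 2 would give a step of similar size.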